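The source may report more compounds than this note shows. Statements on the series, on what has been measured and on what is new or still open speak of the compounds shown alone.

Working notes on the series. For the measured compounds named here, compound 1 `Cc1ccccc1C(=O)Nc1cc(C#N)ccn1` is the only member with a number in a physicochemical assay for solubility, read by nephelometry, measured as kinetic solubility, at pH 2, tested at 10 mg/mL; on this read-out higher numbers stand for higher solubility and lower numbers for lower solubility: compound 1 gives 50 ug/mL. Compound 2 `Cc1ccnc(NC(=O)c2cccc(F)c2C)c1` is reported only as a limit, > 100 ug/mL, in this assay. Compound 3 `Cc1ccccc1C(=O)Nc1cccc(F)n1` is likewise reported only as a limit, > 100 ug/mL, in this assay. Going by the values given here, the remaining values rest at the limit of > 100 ug/mL in this assay, at which 2 of the 3 values shown sit, and no step between measured compounds can be drawn. Compound 4 `Cc1ccccc1C(=O)Nc1cc(Cl)ccn1` differs from compound 1 by chloro in place of cyano on an aromatic carbon. Among the compounds with values here, no measured step covers this change, so any expectation rests on compound 1 alone. A step from compound 1 to compound 4 of a 1.4-fold lower number from compound 1 to compound 4 (0.15 log units; within the scatter) is expected, small and downward, within the usual scatter. Compound 4 is thus estimated at 35 ug/mL, with a range from 12 ug/mL to 100 ug/mL.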

Compound 4, solubility: 25 ug/mL
The estimate for compound 4 lay 1.4-fold (0.15 log units) above the measured number, and the stated range covers the measured number.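

For the compounds shown here, at the aromatic carbon opposite the ring nitrogen, chloro in place of cyano gives a 2.0-fold lower number from compound 1 to compound 4 (0.30 log units; within the scatter) in this assay and so supplies the only readable step at this position. With either group at this carbon the result is a number and not a limit, so this exchange of a nitrile for a halogen leaves no difference beyond the scatter. On these data alone, whether an amine, a carboxylic acid or a methoxy group at this carbon would give a step beyond the scatter stays open. Steps that end on a limit cannot be read, which leaves little to compare: the limit of > 100 ug/mL in this assay, at which 2 of the 4 values shown sit.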